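Methylamino in place of the aminopropoxy chain on compound 1

The source may report more compounds than this note shows. Statements on the series, on what has been measured and on what is new or still open speak of the compounds shown alone.

Two measured compounds frame this step. Compound 1 `CN(C)CCCOc1ccc(Nc2nccc(-c3cccnc3)n2)cc1` is measured in a functional assay for inhibition, with Homo sapiens as the target (on this read-out higher numbers stand for weaker inhibition and lower numbers for stronger inhibition), where compound 1 gives 600 nM. For the measured compounds named here, compound 2 `CN(C)c1ccc(Nc2nccc(-c3cccs3)n2)cc1` is the only other compound measured; in this assay compound 2 gives 900 nM. The two values lie within the usual scatter of each other, so compound 1 stands beside compound 2 rather than apart from it, and no ordering of the two can be read from these numbers.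

Compound 3 `CNc1ccc(Nc2nccc(-c3cccnc3)n2)cc1` has not yet been measured. It differs from compound 1 in one place: methylamino in place of 3-(dimethylamino)propoxy on an aromatic carbon. Going by the values given here, no step between measured compounds shares this change, so nothing in the data shows how large a shift to expect. Among the compounds with values here, the account therefore rests on the single value of compound 1 in this assay, which is 600 nM, and on the fact that a seven-atom chain is exchanged for a two-atom group. Compound 3 is expected to show a modest weakening, a step of a 2.0-fold higher number from compound 1 to compound 3 (0.30 log units; within the scatter), with a wide range. Compound 3 is estimated at 1200 nM, between 300 nM and 5000 nM in this assay.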

Compound 3, half-maximal inhibitory concentration: 2100 nM
Compound 3: middle estimate off by 1.8-fold (0.24 log units), on the low side; low and high end bracket the measured number.
By their numbers in this assay, from the lowest: compounds 1 and 2 (each within the scatter of the next); then compound 3.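

For the compounds shown here, this is the first readable step at this position on the core of compound 1. In this assay, replacing 3-(dimethylamino)propoxy with methylamino on the aromatic carbon gives a 3.5-fold higher number from compound 1 to compound 3 (0.54 log units; beyond the scatter), so what this position carries does matter, although the shift is modest and compound 3 still gives 2100 nM after a chain of 7 heavy atoms gives way to a group of 2 heavy atoms. No available measurement accounts for this shift.

This single step leaves the length of the chain, its ether oxygen and its terminal dimethylamino group tied together, so the compounds shown cannot say which of these parts goes with the lower number of compound 1. A shorter 2-(dimethylamino)ethoxy chain, a simple methoxy group, or a morpholine at the end of the propoxy chain, each on the same core, would begin to separate these parts.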